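Replacing a Ring Group on the Saturated Ring

This account rests on a few compounds, and the source may have more. Where it says the series, first, only, none or still open, it means among the compounds named here.

Compound 1 `O=C([C@H](O)CS(=O)(=O)c1ccc2cc(Cl)ccc2c1)N1CCC(n2cc[nH]c2=O)CC1`: 1.79
Compound 2 `O=C([C@H](O)CS(=O)(=O)c1ccc2cc(Cl)ccc2c1)N1CCC(N2CCCS2(=O)=O)CC1`: 1.69

Within the data shown here, in a physicochemical assay for lipophilicity, measured as octanol-water partition, at pH 7.4 (a lower number here means a more polar compound, a higher number a more lipophilic compound), compound 2 gives 1.69 and lies within the scatter of compound 1 , the only other measured compound. Compound 3 `O=C([C@H](O)CS(=O)(=O)c1ccc2cc(Cl)ccc2c1)N1CCC(N2CCCC2)CC1` differs from compound 2 by a group of 5 heavy atoms (4 carbon, 1 nitrogen; one five-membered non-aromatic ring with 1 hetero atom) in place of a group of 7 heavy atoms (3 carbon, 1 nitrogen, 2 oxygen, 1 sulfur; one five-membered non-aromatic ring with 2 hetero atoms), on a saturated ring carbon. Among the measured compounds shown here, one measured step bears on this, and only loosely. That step, a number 0.10 log units lower from compound 1 to compound 2 (within the scatter), exchanged one ring group for another at the same place. The pyrrolidin-1-yl group, however, occurs in neither measured compound, so the data do not settle the outcome, and the range must stay wide. On the structural change alone, a modest move to a lower number is expected in this assay. The expected size is a number 0.39 log units lower from compound 2 to compound 3 (beyond the scatter). For compound 3 the estimated value is 1.3, with an expected range from 0.6 to 2.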

Compound 3, distribution coefficient: 1.56
Estimate against measurement, compound 3: 0.26 log units below; the range from low to high includes it.
By their numbers in this assay, from the lowest: compounds 3, 2 and 1 (each within the scatter of the next).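

In this assay, the pyrrolidin-1-yl group on this saturated ring carbon stays within the scatter of both earlier compounds: a number 0.13 log units lower from compound 2 to compound 3 (within the scatter) and a number 0.23 log units lower from compound 1 to compound 3 (within the scatter). The three five-membered ring groups at this one place differ in heavy atoms, hetero atoms and hydrogen-bond acceptors, and one of them is aromatic, yet their numbers in this assay cannot be told apart, which one earlier step alone could not show. Nothing at hand gives a reason for this.

Going by these compounds, it remains open whether a group of another kind at this place, such as a carboxylic acid or an open-chain amine, would give a step beyond the scatter. On these data alone, it also remains open whether these ring groups would stay this close on a different core.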